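Dimethylamino Replacing Methylsulfanyl on a Fused Core

The source may report more compounds than this note shows. Statements on the series, on what has been measured and on what is new or still open speak of the compounds shown alone.

Of the compounds shown here, two have been measured in a functional assay on the whole organism (Pleural cavity) with Rattus norvegicus as the target; on this read-out lower numbers stand for an effect already at smaller amounts and higher numbers for an effect only at larger amounts of compound. Compound 1 `CSc1[nH]ccc2ncnc1-2` carries a methylsulfanyl group on its fused core, and in this assay compound 1 gives 9 mg/kg. Compound 2 `OC[C@H]1O[C@@H](n2cnc3cnccc32)C[C@@H]1O` is built quite differently. For compound 2 this assay reports only a limit, > 9 mg/kg, and not a number. Within the data shown here, compound 1 therefore holds the only firm number seen here; the other entry is the limit of > 9 mg/kg in this assay, at which 1 of the 2 values shown sits.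

Compound 3 `CN(C)c1[nH]ccc2ncnc1-2` is compound 1 with a single change: dimethylamino in place of methylsulfanyl on an aromatic carbon. Among the measured compounds shown here, no step between two measured compounds is available to show what such a swap does in this assay, so the expectation for compound 3 rests on compound 1 alone and on the modest size of the change. Compound 3 is expected to give about 12 mg/kg, with a likely range from 4 mg/kg to 35 mg/kg. The step of a 1.3-fold higher number from compound 1 to compound 3 (0.12 log units; within the scatter) is expected to stay within the usual scatter of repeated measurements, neither clearly stronger nor clearly weaker, though a limit rather than a number cannot be ruled out.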

Compound 3, dose for half-maximal effect: 9 mg/kg
Beside the measured number, compound 3's estimate is 1.3-fold (0.12 log units) above it; the measured number falls inside the stated range.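

In this assay, among these compounds, the first direct comparison at this position shows no change at the digits printed from compound 1 to compound 3 (within the scatter), with dimethylamino in place of methylsulfanyl on an aromatic carbon next to the ring nitrogen. The earlier compounds shown here offered no such pair, since compound 1 and compound 2 differ in more than one place. This single pair shows that the sulfur of methylsulfanyl is not needed for the effect on this read-out when dimethylamino takes its place, and that this position accepts the swap of one of these groups for the other without a shift beyond the usual scatter.

As far as these compounds go, whether the position tolerates groups of a different kind stays open, for example a carboxylic acid, a primary amine or a longer chain such as butylsulfanyl on the same carbon, and a plain hydrogen there would show whether a group at this spot matters at all. Compound 2 gives no help with these questions, as its entry is a limit and not a number, and it is built too differently to compare: the limit of > 9 mg/kg in this assay, at which 1 of the 3 values shown sits.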